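Cytotoxicity notes: nitro in place of phenyl on the aryl ring

A few compounds are considered here, and "the series" means these few. Any claim that something is new, unique, unknown or untested is made for them only; others in the source may bear on it.

compound 1 `CCOC(=O)c1c(-c2cccc(C)c2)[nH]c2cc(OC)ccc2c1=O`: > 21500 nM
compound 2 `CCOC(=O)c1c(-c2cccc(-c3ccccc3)c2)[nH]c2cc(OC)ccc2c1=O`: > 21500 nM
compound 3 `CCOC(=O)c1c(-c2cccc(C(C)=O)c2)[nH]c2cc(OC)ccc2c1=O`: > 21500 nM

In an ADME assay on BJ cells (Homo sapiens) for cytotoxicity, read by luminescence, with a stated time of 72 h (on this read-out higher numbers stand for an effect only at larger amounts of compound and lower numbers for an effect already at smaller amounts), compound 1 reaches only the limit > 21500 nM. Compound 2 likewise gives only the limit > 21500 nM in this assay. Compound 3 also stops at the limit > 21500 nM. Compound 2 therefore holds no distinct place among the numbers shown, since all three values sit together at the same limit (the limit of > 21500 nM in this assay, at which 3 of the 3 values shown sit). Compound 4 `CCOC(=O)c1c(-c2cccc([N+](=O)[O-])c2)[nH]c2cc(OC)ccc2c1=O` differs from compound 2 by nitro in place of phenyl on an aromatic carbon. The steps bearing on this change, a step that the two limits leave unreadable from compound 1 to compound 2, a step that the two limits leave unreadable from compound 2 to compound 3 and a step that the two limits leave unreadable from compound 1 to compound 3, have no readable size because every value is a limit (the limit of > 21500 nM in this assay, at which 3 of the 3 values shown sit). No step beyond the scatter is expected. Compound 4 is estimated at 21500 nM, within 9000 nM to 50000 nM. The expected step is a number no higher from compound 2 to compound 4 (the limit leaves the size open), most likely again reported as a limit.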

Compound 4, half-maximal effective concentration: > 21500 nM
Compound 4 ended at the assay's limit (the forecaster's own chance of this, stated with the estimate: 80%); the middle value sits exactly at the limit.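

In this assay no step can be read from compound 4 to compound 1, compound 2 or compound 3, because all values are limits: the limit of > 21500 nM in this assay, at which 4 of the 4 values shown sit.

The compounds shown leave open whether methyl, phenyl, acetyl and nitro differ at all, and at what concentration any of the four compounds acts.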